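This account rests on a few compounds, and the source may have more. Where it says the series, first, only, none or still open, it means among the compounds named here.

Three compounds share one core and differ only in the group carried on a saturated chain carbon bound to an amine nitrogen in a ring: compound 1 `O=c1c2cnn(-c3ccc(F)cc3)c2ncn1CC1(O)CCN(Cc2cccc(Cl)c2)CC1`, compound 2 `O=c1c2cnn(-c3ccc(F)cc3)c2ncn1CC1(O)CCN(Cc2ccc(Cl)cc2)CC1` and compound 3 `Cc1ccc(CN2CCC(O)(Cn3cnc4c(cnn4-c4ccc(F)cc4)c3=O)CC2)cc1`. Of these, only compound 2 has a number in an assay on Sf21 cells for inhibition of ubiquitin carboxyl-terminal hydrolase 7 (Homo sapiens), read by spectrophotometry, with stated times of 30 min and 2 h (on this read-out lower numbers stand for stronger inhibition and higher numbers for weaker inhibition), where compound 2 gives 8000 nM. In this assay compound 1 gives "not determined" (no result reported). In this assay, among the measured compounds shown here, compound 3 gives "not determined" (no result reported), so compound 3 stands without a number and no measured step can be drawn from it. Compound 4 `COC(=O)c1ccc(CN2CCC(O)(Cn3cnc4c(cnn4-c4ccc(F)cc4)c3=O)CC2)c(Br)c1` is the next compound to be tested in this assay; it differs from compound 3 by 2-bromo-4-(methoxycarbonyl)phenyl in place of 4-methylphenyl on a saturated chain carbon bound to an amine nitrogen in a ring. For the measured compounds named here, with no step known between measured compounds, the expected size and direction of the change from compound 3 to compound 4 are open. Compound 4 is expected to give about 6000 nM, in a range from 1500 nM to 25000 nM.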

Compound 4, half-maximal inhibitory concentration: 900 nM
Estimate against measurement, compound 4: 6.7-fold (0.82 log units) above; measured number outside the range, below it.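

In this assay there is an 8.9-fold lower number from compound 2 to compound 4 (0.95 log units; beyond the scatter) when 2-bromo-4-(methoxycarbonyl)phenyl takes the place of 4-chlorophenyl, so this position can carry a phenyl bearing both bromine and an ester and still give a lower number. Steps involving compound 1 or compound 3 cannot be read. No measurement shown here accounts for the change.

Going by these compounds, whether the bromine or the methoxycarbonyl group drives the step stays open, since the two enter together. On these data alone, how a carboxylic acid or an amide in place of the ester would read also remains open.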